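The source may report more compounds than this note shows. Statements on the series, on what has been measured and on what is new or still open speak of the compounds shown alone.

Of the compounds shown here, two have been measured in a functional assay on TK-10 cells (Homo sapiens) for inhibition; a lower number here means a stronger inhibitor of growth, a higher number a weaker inhibitor of growth. Compound 1 `O=C(/C=C/c1cccc(O)c1)c1cccc(-n2cc(-c3ccc(Cl)cc3)[nH]c2=O)c1` gives 2830 nM. Compound 2 `COc1ccc(-c2cn(-c3cccc(C(=O)/C=C/c4ccc(O)c(OC)c4)c3)c(=O)[nH]2)cc1` gives 6080 nM, the highest of the two numbers; the gap to compound 1 lies beyond the usual scatter. Compound 1 and compound 2 differ in more than one place, so their two values alone cannot say which change carries that gap.

Compound 3 `COc1cc(/C=C/C(=O)c2cccc(-n3cc(-c4ccc(Cl)cc4)[nH]c3=O)c2)ccc1O` has not yet been measured. It differs from compound 2 in one place: chloro in place of methoxy on an aromatic carbon. In other words, compound 3 keeps the enone side of compound 2 but carries the 4-chlorophenyl group found in compound 1.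

Among the compounds with values here, with no single-change step measured between the known compounds, the expectation rests on what the two values show. The lower number of compound 1 at 2830 nM hints that the chloro-bearing compounds may be stronger growth inhibitors, but that hint is tangled with the second difference. Compound 3 is therefore expected to land modestly below compound 2, with the estimated step of a 1.7-fold lower number from compound 2 to compound 3 (0.24 log units; within the scatter) not far beyond the scatter. The expected value for compound 3 is 3500 nM, within a range from 1500 nM to 8000 nM.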

Compound 3, concentration for 50% growth inhibition: 4670 nM
Compound 3: middle estimate off by 1.3-fold (0.13 log units), on the low side; the measured number falls inside the stated range.
By their numbers in this assay, from the lowest: compounds 1, 3 and 2 (each within the scatter of the next, the first and the last beyond it).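

In this assay, placing chloro where methoxy stood gives a 1.3-fold lower number from compound 2 to compound 3 (0.11 log units; within the scatter), so at this position, para to a large group, the 4-methoxyphenyl and 4-chlorophenyl versions cannot be told apart when the 4-hydroxy-3-methoxyphenyl group is present. The other single change, 4-hydroxy-3-methoxyphenyl in place of 3-hydroxyphenyl with the 4-chlorophenyl group held fixed, gives a 1.7-fold higher number from compound 1 to compound 3 (0.22 log units; within the scatter), which means that neither step alone accounts for a difference beyond the scatter, and the earlier gap between compound 1 and compound 2 cannot be assigned to one place. No measurement here explains why these two groups read alike in this assay.

Only chloro and methoxy are shown at this position, so it remains open whether a quite different group there, such as an amine or a carboxylic acid, would move the number beyond the scatter. It also remains open whether swapping methoxy for chloro would read the same with the 3-hydroxyphenyl group of compound 1 in place, since that single change is shown only with the 4-hydroxy-3-methoxyphenyl group.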